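The source may hold more compounds than are shown below. What is called first, only, known or untested is meant among the compounds shown, and "the series" means these compounds.

Of the compounds shown here, three sharing one core have been measured in an assay on CHO cells for antagonist activity at transient receptor potential cation channel subfamily V member 1 (Homo sapiens), read by FLIPR; on this read-out higher numbers stand for weaker inhibition and lower numbers for stronger inhibition. Compound 1 `CC(C(=O)NCc1ccc(C(F)(F)F)nc1-c1ccc(F)c(Cl)c1)c1ccc(NS(C)(=O)=O)c(F)c1` gives 0.2 nM, compound 2 `CC(C(=O)NCc1ccc(C(F)(F)F)nc1-c1ccoc1)c1ccc(NS(C)(=O)=O)c(F)c1` gives 1.4 nM, and compound 3 `CC(C(=O)NCc1ccc(C(F)(F)F)nc1C#Cc1ccccc1)c1ccc(NS(C)(=O)=O)c(F)c1` gives 0.8 nM. Compound 3 thus stands second highest of the three numbers, with a 1.8-fold lower number from compound 2 to compound 3 (0.24 log units; within the scatter) and a 4.0-fold higher number from compound 1 to compound 3 (0.60 log units; beyond the scatter). Compound 4 `Cc1ccc(CCc2nc(C(F)(F)F)ccc2CNC(=O)C(C)c2ccc(NS(C)(=O)=O)c(F)c2)cc1` differs from compound 3 by 2-(4-methylphenyl)ethyl in place of 2-phenylethynyl on an aromatic carbon. The measured steps at this position, a 7.0-fold higher number from compound 1 to compound 2 (0.85 log units; beyond the scatter) and a 4.0-fold higher number from compound 1 to compound 3 (0.60 log units; beyond the scatter), were both modest, so a further change there is expected to shift the number in this assay only modestly, if at all, more likely toward a higher value. Compound 4 is therefore estimated at 1.5 nM, within 0.4 nM to 6 nM. The expected step is a 1.9-fold higher number from compound 3 to compound 4 (0.27 log units; within the scatter).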

Compound 4, inhibition constant: 0.6 nM
For compound 4 the middle estimate is 2.5-fold (0.40 log units) above the measured one; the measured number falls inside the stated range.
By their numbers in this assay, from the lowest: compound 1; then compounds 4, 3 and 2 (each within the scatter of the next, the first and the last beyond it).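

In this assay, 2-(4-methylphenyl)ethyl, which carries no triple bond, does as well at this position as 2-phenylethynyl, with a 1.3-fold lower number from compound 3 to compound 4 (0.12 log units; within the scatter), so the triple bond is not required for a low number here. The same group shows a 2.3-fold lower number from compound 2 to compound 4 (0.37 log units; beyond the scatter) and a 3.0-fold higher number from compound 1 to compound 4 (0.48 log units; beyond the scatter), which leaves 3-chloro-4-fluorophenyl with the lowest number among these groups. No measured evidence bears on why these steps take this size. The compounds shown leave open what an amine or a longer chain ending in a phenyl ring would give at this place. They also leave open how the methyl and the triple bond each count on their own.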